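Dropping one methoxy from the aryl ring of compound 2

A few compounds are considered here, and "the series" means these few. Any claim that something is new, unique, unknown or untested is made for them only; others in the source may bear on it.

Compound 2 `COc1ccc(C2CC(c3cccc4ccccc34)=NN2C(C)=O)c(OC)c1OC` and compound 1 `COc1cc(C2CC(c3cccc4ccccc34)=NN2C(C)=O)cc(OC)c1OC` share a core and differ only in how the three methoxy groups sit on the six-membered ring. In a functional assay on PC-3 cells (Homo sapiens) for cytotoxicity, read by sulforhodamine B assay, with a stated time of 48 h (a higher number here means a weaker inhibitor, a lower number a stronger inhibitor), compound 2 gives 1220 nM, and compound 1 gives 1090 nM; the two stand within the scatter of each other, so neither can be set apart. Compound 3 `COc1ccc(C2CC(c3cccc4ccccc34)=NN2C(C)=O)cc1OC` is not yet measured. Its change from compound 2 is hydrogen in place of methoxy on an aromatic carbon. Going by the values given here, no measured pair shows this step, so the expected size rests on nothing firmer than the two numbers in hand; the step from compound 2 to compound 3 is expected to be a modest weakening, a 2.0-fold higher number from compound 2 to compound 3 (0.31 log units; beyond the scatter). In this assay compound 3 is estimated at 2500 nM, likely between 900 nM and 8000 nM.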

Compound 3, half-maximal inhibitory concentration: 2010 nM
Compound 3: the middle estimate sits 1.2-fold (0.09 log units) above what was measured, and the stated range covers the measured number.
By their numbers in this assay, from the lowest: compounds 1, 2 and 3 (each within the scatter of the next).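

In this assay, hydrogen in place of methoxy on an aromatic carbon, ortho to a large group, gives a 1.6-fold higher number from compound 2 to compound 3 (0.22 log units; within the scatter), and the same exchange gives a 1.8-fold higher number from compound 1 to compound 3 (0.27 log units; within the scatter). Going by these compounds alone, the ring of compound 3 therefore carries only two methoxy groups, yet it cannot be set apart from compound 1 or compound 2 in this cell read-out. Nothing available explains these numbers.

Going by these compounds, whether a hydroxyl, an amine or a fluorine at this position would separate from methoxy remains open. So does the effect of replacing the two remaining methoxy groups.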